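Thian-4-yl for piperidin-4-yl at the chain amine

The source may report more compounds than this note shows. Statements on the series, on what has been measured and on what is new or still open speak of the compounds shown alone.

Compound 2 `c1ccc2c(c1)CN[C@@H](CN(CCCCNC1CCNCC1)[C@H]1CCCc3cccnc31)C2` gives 63.4 nM in a functional assay on cells for antagonist activity at C-X-C chemokine receptor type 4 (Homo sapiens), read by fluorescence and calcium flux, with stated times of 25 min and 90 s (on this read-out higher numbers stand for weaker inhibition and lower numbers for stronger inhibition), the higher of the two numbers in hand; its nearest neighbour, compound 1 `c1ccc2c(c1)CN[C@@H](CN(CCCCNCc1ccncc1)[C@H]1CCCc3cccnc31)C2`, gives 22.7 nM in this assay. Going by the values given here, the only measured step at this position is the exchange that leads to compound 2: a 2.8-fold higher number from compound 1 to compound 2 (0.45 log units; beyond the scatter). Compound 3 `c1ccc2c(c1)CN[C@@H](CN(CCCCNC1CCSCC1)[C@H]1CCCc3cccnc31)C2` continues from compound 2 by thian-4-yl in place of piperidin-4-yl on an amine nitrogen. Among the compounds with values here, no measured step tests the loss of the ring donor or the change of the ring hetero atom, so the step to compound 3 can only be placed by analogy with the neighbouring exchange on the same amine nitrogen, which was modest and weakening. A modest further weakening is therefore the expectation, estimated as a 2.4-fold higher number from compound 2 to compound 3 (0.37 log units; beyond the scatter). Compound 3 is expected to give about 150 nM in this assay, with a range from 50 nM to 450 nM.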

Compound 3, half-maximal inhibitory concentration: 54.7 nM
For compound 3 the middle estimate is 2.7-fold (0.44 log units) above the measured one; low and high end bracket the measured number.
By their numbers in this assay, from the lowest: compound 1; then compounds 3 and 2 (each within the scatter of the next).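

In this assay the exchange of piperidin-4-yl for thian-4-yl on the amine nitrogen gives a 1.2-fold lower number from compound 2 to compound 3 (0.06 log units; within the scatter) and so lies within the scatter: the ring nitrogen and its hydrogen-bond donor can give way to sulfur, with no donor in the ring, without a change this read-out can resolve. Set against (pyridin-4-yl)methyl, thian-4-yl gives a 2.4-fold higher number from compound 1 to compound 3 (0.38 log units; beyond the scatter) and so falls on the same side of compound 1 as piperidin-4-yl does in compound 2. Nothing at hand accounts for either step.

Open, on these data alone, is whether a cyclohexyl or an oxan-4-yl group on the same amine nitrogen would stay level with compound 2 and compound 3. Also open, as far as these compounds go, is whether the lower number of compound 1 goes with its pyridine nitrogen, which a benzyl group there would test.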